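Nitro to Trifluoromethyl on a Shared Core

The source may hold more compounds than are shown below. What is called first, only, known or untested is meant among the compounds shown, and "the series" means these compounds.

Three compounds built on one core carry a nitro group at different places. Compound 1 `COc1cc2ncnc(Nc3cccc([N+](=O)[O-])c3)c2c(OC)c1OC` gives 26.4% in a functional assay on PC-3 cells (Homo sapiens) for inhibition, read by MTT assay, with a stated time of 72 h, tested at 10 uM; on this read-out lower numbers stand for less inhibition of growth and higher numbers for more inhibition of growth at the one concentration tested. Compound 2 `COc1cc2ncnc(Nc3ccc([N+](=O)[O-])cc3)c2c(OC)c1OC` gives 24.9% in this assay, and compound 3 `COc1cc2ncnc(Nc3ccccc3[N+](=O)[O-])c2c(OC)c1OC` gives 25.5%. Compound 1 shows the largest of the three numbers, yet its gaps to compound 3 and to compound 2 both fall within the scatter, so the three cannot be told apart on these readings.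

Compound 4 `COc1cc2ncnc(Nc3cccc(C(F)(F)F)c3)c2c(OC)c1OC` has not been measured. It differs from compound 1 by trifluoromethyl in place of nitro on an aromatic carbon. Within the data shown here, no pair among the measured compounds shows a step of this kind, and the three nitro isomers give no sign that the group matters much here. The step from compound 1 to compound 4 is therefore expected to be small, close to no change beyond the scatter, with only a slight lean upward: a number 1.6 percentage points higher from compound 1 to compound 4 (within the scatter). Compound 4 is accordingly estimated at 28%, within a range from 12% to 50%.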

Compound 4, percent growth inhibition at one concentration: 46.6%
The estimate for compound 4 lay 18.6 percentage points below the measured number; low and high end bracket the measured number.
By their numbers in this assay, from the lowest: compounds 2, 3 and 1 (each within the scatter of the next); then compound 4.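

Trifluoromethyl in place of nitro on this aromatic carbon, meta to a large group, gives a number 20.2 percentage points higher from compound 1 to compound 4 (beyond the scatter) in this assay. The group at this place therefore does matter for growth inhibition at the one concentration tested, something the three nitro isomers, all within the scatter of one another, gave no sign of. Nothing at hand accounts for a step of this size.

Going by these compounds, whether this higher number belongs to trifluoromethyl in particular, or would also come with another group at this place, such as a chlorine atom, a methyl group or an amine, stays open. Also open, on these data alone, is whether trifluoromethyl at the other two places that the nitro group occupies in the isomers would give a similar number.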